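The source may report more compounds than this note shows. Statements on the series, on what has been measured and on what is new or still open speak of the compounds shown alone.

In a functional assay, read by spectrophotometry, tested at 100 uM (on this read-out lower numbers stand for stronger inhibition and higher numbers for weaker inhibition), compound 2 `O=C(/C=C/c1ccco1)c1cccc(NC(=O)c2cc(-c3ccncc3)n[nH]2)c1` gives 41800 nM and compound 1 `O=C(/C=C/c1cccc2ccccc12)c1cccc(NC(=O)c2cc(-c3ccncc3)n[nH]2)c1` gives 64500 nM so that the two stand within the scatter of each other. Compound 3 `O=C(/C=C/c1ccccc1Cl)c1cccc(NC(=O)c2cc(-c3ccncc3)n[nH]2)c1` differs from compound 2 by 2-chlorophenyl in place of furan-2-yl on a double-bonded chain carbon bound to a double-bonded chain carbon with 2-chlorophenyl in place of furan-2-yl on a double-bonded chain carbon bound to a double-bonded chain carbon. Among the compounds with values here, the one measured step at this place is a 1.5-fold lower number from compound 1 to compound 2 (0.19 log units; within the scatter) and it stays within the scatter, so no step beyond the scatter is expected in this assay here. The estimated step is a 1.2-fold higher number from compound 2 to compound 3 (0.08 log units; within the scatter) and is expected to stay within the scatter. For compound 3 the estimated value is 50000 nM with 22000 nM to 100000 nM as its expected span.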

Compound 3, half-maximal inhibitory concentration: 27700 nM
Beside the measured number, compound 3's estimate is 1.8-fold (0.26 log units) above it, and the stated range covers the measured number.
By their numbers in this assay, from the lowest: compounds 3, 2 and 1 (each within the scatter of the next, the first and the last beyond it).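

In this assay, this place on the double-bonded chain carbon gives its first step beyond the scatter, though a modest one: 2-chlorophenyl in place of naphthalen-1-yl gives a 2.3-fold lower number from compound 1 to compound 3 (0.37 log units; beyond the scatter). With 2-chlorophenyl in place of furan-2-yl, the result is a 1.5-fold lower number from compound 2 to compound 3 (0.18 log units; within the scatter), so this change cannot be told from repeat variation. Nothing available accounts for either step. The compounds shown leave open how an amine or a carboxylic acid on the ring at this place would read in this assay.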